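Adding a Fluoro Group to Compound 2

The source may hold more compounds than are shown below. What is called first, only, known or untested is meant among the compounds shown, and "the series" means these compounds.

Compound 1 `CCCCNc1nc(NCc2ccco2)c2ccccc2n1`, compound 2 `Cc1cccc(N2CCN(CCCNc3nc(NCc4ccco4)c4ccccc4n3)CC2)c1C` and compound 3 `CN(C)CCNc1nc(NCc2ccco2)c2ccccc2n1` share one core. In a functional assay on A375P cells (Homo sapiens) for cytotoxicity, read by MTT assay, with a stated time of 2 days (on this read-out lower numbers stand for stronger inhibition and higher numbers for weaker inhibition), compound 1 gives 9200 nM, while compound 2 gives 3040 nM, the lowest of the two numbers recorded, and its distance from compound 1 lies beyond the scatter; for compound 3 the entry reads "not determined" (no result reported), so no number is available for it. Compound 4 `Cc1cccc(N2CCN(CCCNc3nc(NCc4ccco4)c4cc(F)ccc4n3)CC2)c1C` differs from compound 2 only in fluoro in place of hydrogen on an aromatic carbon. Among the measured compounds shown here, no pair of measured compounds shows such a change, so the size of this step in this assay cannot be read from the data; a single added fluorine is expected to shift the number little, probably not beyond the scatter. Compound 4 is therefore estimated at about 2500 nM, between 1000 nM and 7000 nM. The step of a 1.2-fold lower number from compound 2 to compound 4 (0.08 log units; within the scatter) that this estimate implies is expected to stay within the scatter.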

Compound 4, half-maximal inhibitory concentration: 2830 nM
For compound 4 the middle estimate is 1.1-fold (0.05 log units) below the measured one; the range from low to high includes it.
By their numbers in this assay, from the lowest: compounds 4 and 2 (each within the scatter of the next); then compound 1.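

The swap of fluoro in place of hydrogen on an aromatic carbon can now be read directly in this assay as a 1.1-fold lower number from compound 2 to compound 4 (0.03 log units; within the scatter) and so does not separate the two compounds. At this position on the six-membered aromatic ring of the shared core, the added fluoro group therefore leaves the number within the scatter. Nothing on hand offers an explanation for this result.

On these data alone, whether chloro, methoxy or an amine on the same carbon would also stay within the scatter remains open. So does the outcome of fluoro on another carbon of that ring.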